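Extending the methoxy group of compound 3

The compounds below may be only part of what the source reports. "The series", "measured", "known", "first", "only" and "open" are said of these compounds alone.

Measured in a functional assay on MCF7 cells (Homo sapiens) for inhibition, read by radiometric assay and XTT assay; a higher number here means a weaker inhibitor, a lower number a stronger inhibitor
compound 1 `C/C=C/C(C)=C/[C@@]1(C)SC(O)=CC1=O` gives > 80 ug/mL (a limit)
compound 2 `CCCCCC[C@@]1(C)SC(O)=CC1=O` gives > 80 ug/mL (a limit)
compound 3 `CCCCCCCC[C@@]1(C)SC(=O)C=C1OC` gives 16.4 ug/mL

Among the measured compounds shown here, compound 3 gives the only actual number in this set (16.4 ug/mL). Compound 1 and compound 2 give no number, only (the limit of > 80 ug/mL in this assay, at which 2 of the 3 values shown sit). Compound 4 `CCCCCCCC[C@@]1(C)SC(=O)C=C1OCC(=O)OCC` has ethoxycarbonyl in place of hydrogen on a saturated chain carbon bound to an oxygen on an unsaturated carbon, turning methoxy into (ethoxycarbonyl)methoxy. For the measured compounds named here, no measured pair in this set shows such a change. In this assay only a small shift toward weaker inhibition is expected, possibly within the scatter. The estimate is a 1.3-fold higher number from compound 3 to compound 4 (0.13 log units; within the scatter). For compound 4 the expected value is 22 ug/mL, with an estimated range from 8 ug/mL to 60 ug/mL.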

Compound 4, half-maximal inhibitory concentration: 35.3 ug/mL
Beside the measured number, compound 4's estimate is 1.6-fold (0.21 log units) below it, and the stated range covers the measured number.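

In this assay, replacing methoxy with (ethoxycarbonyl)methoxy keeps measurable inhibition, with a 2.2-fold higher number from compound 3 to compound 4 (0.33 log units; beyond the scatter). Among the compounds shown here, this is the only measured step at this position, and it shows that the position accepts the ethoxycarbonyl group at a modest cost, with compound 4 still giving a number rather than a limit. No other compound shown offers a number to compare with these two: the limit of > 80 ug/mL in this assay, at which 2 of the 4 values shown sit. Going by these compounds, whether a carboxylic acid or an amine in place of the ethoxycarbonyl would keep this level of inhibition remains open, as does the effect of a longer chain on that oxygen.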